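A few compounds are considered here, and "the series" means these few. Any claim that something is new, unique, unknown or untested is made for them only; others in the source may bear on it.

Compound 1 `CCC/N=c1\c(O)c(O)\c1=N/c1cccnc1` in a functional assay for inhibition, with Rattus norvegicus as the target; a lower number here means a stronger inhibitor, a higher number a weaker inhibitor: > 30000 nM (a limit)
Compound 2 `Cc1cc(C#N)ccc1/N=c1\c(O)c(O)\c1=N/[C@H](C)C(C)(C)C` in this assay: 1080 nM

The entry for compound 1, > 30000 nM, is a limit of the assay and not a number. Within the data shown here, that leaves compound 2, at 1080 nM, as the only actual number available in this assay.

Compound 3 `C[C@@H](/N=c1\c(O)c(O)\c1=N/c1ccc(C#N)cc1Br)C(C)(C)C` has not yet been measured. It departs from compound 2 in one place: bromo in place of methyl on an aromatic carbon. In short, it has bromo in place of methyl on an aromatic carbon. Among the measured compounds shown here, no measured pair shows this kind of swap, so the only anchor is compound 2 at 1080 nM. No change beyond the usual scatter is expected in this assay, and the expected step is a 1.1-fold lower number from compound 2 to compound 3 (0.03 log units; within the scatter). The expected value for compound 3 is 1000 nM, with an estimated range of 300 nM to 3500 nM.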

Compound 3, half-maximal inhibitory concentration: 75 nM
The estimate for compound 3 lay 13-fold (1.12 log units) above the measured number; the measured number lies below the stated range.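

In this assay, bromo in place of methyl gives a 14-fold lower number from compound 2 to compound 3 (1.16 log units; beyond the scatter), so this aromatic carbon, ortho to a large group and meta to a cyano group, matters to the read-out. Among these compounds, the swap exchanges one heavy atom for one heavy atom, with no ring, hydrogen-bond donor, hydrogen-bond acceptor or net charge entering or leaving, yet the step lies well beyond the scatter, which the earlier compounds could not show because they offered no pair to compare. Nothing shown here bears on why bromo gives the lower number.

The compounds shown leave open how chloro, trifluoromethyl, methoxy or a plain hydrogen would fare on this carbon. Among the compounds shown here, this is also only one pair, so whether the same swap gives a similar step on a different group at the other side of the core remains unknown.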